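The source may hold more compounds than are shown below. What is called first, only, known or untested is meant among the compounds shown, and "the series" means these compounds.

Compound 1 `COC(=O)c1cc(-c2cccc(NC(=O)c3ccc(/C=C/C(=O)c4cc(OC)c(OC)c(OC)c4)cc3)c2)on1` was examined in an ADME assay on Vero cells (Chlorocebus sabaeus) for cytotoxicity, read by MTT assay, with a stated time of 72 h; on this read-out higher numbers stand for lower toxicity in this test and lower numbers for higher toxicity in this test. In this assay compound 1 gives only a limit, > 50 ug/mL. Compound 2 `CCOc1ccc(C(=O)/C=C/c2ccc(C(=O)Nc3cccc(-c4cc(C(=O)OC)no4)c3)cc2)cc1` likewise gives a limit in this assay, > 40 ug/mL. Compound 3 `COC(=O)c1cc(-c2cccc(NC(=O)c3ccc(/C=C/C(=O)c4ccc(C)c(F)c4)cc3)c2)on1` also gives a limit in this assay, > 50 ug/mL. The steps a step that the two limits leave unreadable from compound 1 to compound 2, a step that the two limits leave unreadable from compound 1 to compound 3 and a step that the two limits leave unreadable from compound 2 to compound 3 therefore cannot be sized, as the limit of > 40 ug/mL in this assay, at which 1 of the 3 values shown sits, and the limit of > 50 ug/mL in this assay, at which 2 of the 3 values shown sit, show. Compound 4 `COC(=O)c1cc(-c2cccc(NC(=O)c3ccc(/C=C/C(=O)c4cccc(Cl)c4)cc3)c2)on1` differs from compound 1 by 3-chlorophenyl in place of 3,4,5-trimethoxyphenyl on a carbonyl carbon. All measured exchanges of the aryl group on this carbonyl carbon left the read-out at a limit, so no step beyond the scatter is expected in this assay, and a further limit is the likely outcome. Compound 4 is thus expected to give 50 ug/mL, within 25 ug/mL to 100 ug/mL, an estimated step of a number no higher from compound 1 to compound 4 (the limit leaves the size open).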

Compound 4, half-maximal cytotoxic concentration: > 2.5 ug/mL
Compound 4: only a limit was reported (the forecaster's own chance of this, stated with the estimate: 80%); the middle value does not contradict the limit.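

In this assay compound 4 gives only a limit, > 2.5 ug/mL. Its steps from compound 1, compound 2 and compound 3 therefore cannot be read. The compounds shown leave open whether exchanging the aryl group on this carbonyl carbon changes the half-maximal cytotoxic concentration at all.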